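Capping the Carboxy Group of Compound 3 with Ethyl

A few compounds are considered here, and "the series" means these few. Any claim that something is new, unique, unknown or untested is made for them only; others in the source may bear on it.

Compound 1, `c1ccc2nc(COc3ccc(Cc4nnn[nH]4)cc3)ccc2c1`, gives 1000 nM in a functional assay (Cavia porcellus) for inhibition of cysteinyl leukotriene receptor (Homo sapiens); on this read-out higher numbers stand for weaker inhibition and lower numbers for stronger inhibition.
Compound 2, `c1ccc2nc(COc3ccc(SCCCc4nnn[nH]4)cc3)ccc2c1`, gives 25 nM.
Compound 3, `O=C(O)CCCOc1ccc(OCc2ccc3ccccc3n2)cc1`, gives 800 nM.

Compound 3 holds the second highest of the three numbers. It sits close to compound 1, since a 1.3-fold lower number from compound 1 to compound 3 (0.10 log units; within the scatter), and far from compound 2, since a 32-fold higher number from compound 2 to compound 3 (1.51 log units; beyond the scatter). The new compound 4, `CCOC(=O)CCCOc1ccc(OCc2ccc3ccccc3n2)cc1`, differs from compound 3 by ethyl in place of hydrogen on an oxygen next to a carbonyl group, that is carboxy to ethoxycarbonyl.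

Among the compounds with values here, no measured step touches this position. The large step of a 40-fold lower number from compound 1 to compound 2 (1.60 log units; beyond the scatter) changed the tail carrying the five-membered ring, and the step from compound 1 to compound 3 exchanged one end group for another while staying within the scatter; in every measured compound an uncapped acid or a tetrazole was present. The measured steps therefore give no direct guide, and the expectation rests on the change itself. Compound 4 is expected to show a weaker inhibition, with an expected step of a 3.8-fold higher number from compound 3 to compound 4 (0.57 log units; beyond the scatter). The estimate for compound 4 is 3000 nM, with a range from 700 nM to 15000 nM.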

Compound 4, half-maximal inhibitory concentration: 2000 nM
Estimate against measurement, compound 4: 1.5-fold (0.18 log units) above, and the stated range covers the measured number.
By their numbers in this assay, from the lowest: compound 2; then compounds 3, 1 and 4 (each within the scatter of the next, the first and the last beyond it).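

Capping the carboxy group as ethoxycarbonyl has only a modest effect in this assay, with a 2.5-fold higher number from compound 3 to compound 4 (0.40 log units; beyond the scatter), so an uncapped acid is not required for measurable inhibition in this series. Compound 4 cannot be told apart from the tetrazole compound 1, with a 2.0-fold higher number from compound 1 to compound 4 (0.30 log units; within the scatter), yet it remains far from the tetrazole compound 2, with an 80-fold higher number from compound 2 to compound 4 (1.90 log units; beyond the scatter). Nothing available explains why adding ethyl at this oxygen shifts the number.

Open, going by these compounds, is whether methyl or a longer chain in place of ethyl on this oxygen would give a number close to that of compound 3 or compound 4, and how an amide in place of the ethoxycarbonyl group would read. Also open, on these data alone, is whether ethyl on the tetrazole of compound 2 would shift the number by a similar step.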